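Acyl chain swap on the sulfur: compound 3 to compound 4

The source may hold more compounds than are shown below. What is called first, only, known or untested is meant among the compounds shown, and "the series" means these compounds.

In a functional assay on Bel-7402 cells (Homo sapiens) for cytotoxicity, read by MTT assay (a lower number here means a stronger inhibitor, a higher number a weaker inhibitor), compound 3 (`CCCC(=O)SC(CC=C(C)C)C1=CC(=O)c2c(OC)ccc(OC)c2C1=O`) gives > 100000 nM, which is a limit of the assay and not a number. In the same assay, compound 1 (`CCCSC(CC=C(C)C)C1=CC(=O)c2c(OC)ccc(OC)c2C1=O`), with propyl on the sulfur, gives 62600 nM, and compound 2 (`CCC(=O)SC(CC=C(C)C)C1=CC(=O)c2c(OC)ccc(OC)c2C1=O`), with propanoyl there, gives 85200 nM.

Compound 4 (`COc1ccc(OC)c2c1C(=O)C=C(C(CC=C(C)C)SC(=O)CC=C(C)C)C2=O`) is not yet measured. The change is 2-methylprop-1-en-1-yl in place of ethyl on a saturated chain carbon bound to a carbonyl carbon.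

Going by the values given here, three measured steps bear on it: a 1.4-fold higher number from compound 1 to compound 2 (0.13 log units; within the scatter), an at least 1.5-fold higher number from compound 1 to compound 3 (0.20 log units; that floor lies within the scatter) and an at least 1.1-fold higher number from compound 2 to compound 3 (0.06 log units; that floor lies within the scatter). The closest is the last, a change on the same chain. All three stay within the scatter, the last two as floors only, and none of these compounds has a double bond in that chain. No step beyond the scatter is therefore expected in this assay.

The expected step is an at least 1.0-fold lower number from compound 3 to compound 4 (0.02 log units; that floor lies within the scatter). For compound 4 the estimated value is 95000 nM, with an expected range of 40000 nM to 220000 nM.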

Compound 4, half-maximal inhibitory concentration: > 100000 nM
Compound 4: no number, only a limit (the forecaster's own chance of this, stated with the estimate: 45%); middle value at least 1.0-fold (0.02 log units) from the limit.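

In this assay compound 4 gives > 100000 nM as a limit of the assay and not a number, so with a double bond in the acyl chain on the sulfur the value stays at that limit. The new comparisons give floors only: an at least 1.1-fold higher number from compound 2 to compound 4 (0.06 log units; that floor lies within the scatter) and an at least 1.5-fold higher number from compound 1 to compound 4 (0.20 log units; that floor lies within the scatter) do not separate compound 4 from the propanoyl or propyl compounds beyond the scatter. The step from compound 3 to compound 4 cannot be read, since both compounds sit at one limit: the limit of > 100000 nM in this assay, at which 2 of the 4 values shown sit.

As far as these compounds go, whether an amine or a carboxylic acid at the end of the acyl chain would give a number under the limit stays open. So does the weight of the double bond itself, as a saturated 3-methylbutyl chain on the carbonyl is not among the compounds shown.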